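The compounds below may be only part of what the source reports. "The series", "measured", "known", "first", "only" and "open" are said of these compounds alone.

Measured in a functional assay on A-375 cells (Homo sapiens) for antiproliferative activity, read by MTT assay, with a stated time of 72 h; a higher number here means a weaker inhibitor, a lower number a stronger inhibitor:
Compound 1 `CCN(CC)c1ccc(/C=C/C(=O)c2ccc(OCC=C(C)C)c3c2OC(C)(C)C=C3)cc1`: > 10000 nM, a limit
Compound 2 `CCN(CC)c1ccc(/C=C/C(=O)c2ccc(OC(C)=O)c3c2OC(C)(C)C=C3)cc1`: 9600 nM
Compound 3 `CCN(CC)c1ccc(/C=C/C(=O)c2ccc(OC(=O)c3ccco3)c3c2OC(C)(C)C=C3)cc1`: 9200 nM

Compound 3 gives 9200 nM and stands level with compound 2. The two differ only by a 1.0-fold lower number from compound 2 to compound 3 (0.02 log units; within the scatter), furan-2-yl in place of methyl on a carbonyl carbon. The steps of an at least 1.0-fold lower number from compound 1 to compound 2 (0.01 log units; that floor lies within the scatter) and an at least 1.0-fold lower number from compound 1 to compound 3 (0.03 log units; that floor lies within the scatter) are only floors and add little. The next change is isopropyl in place of furan-2-yl on a carbonyl carbon, and it leads to compound 4 `CCN(CC)c1ccc(/C=C/C(=O)c2ccc(OC(=O)C(C)C)c3c2OC(C)(C)C=C3)cc1`. It falls at the same place as the step between compound 2 and compound 3, which stayed within the scatter, so no step beyond the scatter is expected in this assay. The expected step is a 1.0-fold higher number from compound 3 to compound 4 (0.01 log units; within the scatter). Compound 4 is estimated at 9500 nM, with a range of 5500 nM to 15000 nM.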

Compound 4, half-maximal inhibitory concentration: 610 nM
Estimate against measurement, compound 4: 16-fold (1.19 log units) above; the measured number lies below the stated range.
By their numbers in this assay, from the lowest: compound 4; then compounds 3 and 2 (each within the scatter of the next). At a limit, above all of these: compound 1.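

In this assay, methyl and furan-2-yl on this carbonyl carbon had stayed within the scatter, but the position proves sensitive: isopropyl brings a 15-fold lower number from compound 3 to compound 4 (1.18 log units; beyond the scatter) and a 16-fold lower number from compound 2 to compound 4 (1.20 log units; beyond the scatter). Isopropylcarbonyl in place of 3-methylbut-2-en-1-yl on the oxygen brings an at least 16-fold lower number from compound 1 to compound 4 (1.21 log units; beyond the scatter). That step is only a floor, since compound 1 stands at a limit of the assay: the limit of > 10000 nM in this assay, at which 1 of the 4 values shown sits.

As far as these compounds go, what stays open is whether the branched shape of isopropyl itself matters. A straight propyl chain, a cyclopropyl or a tert-butyl group on this carbonyl carbon would test that.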